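Series notes: core variants in the Chk2 binding assay

This account rests on a few compounds, and the source may have more. Where it says the series, first, only, none or still open, it means among the compounds named here.

Measured so far:
compound 1 `Cc1cc2[nH]nc(N)c2c(=O)[nH]1`: 27%
compound 2 `CC(C)(C)c1cc2[nH]nc(N)c2c(=O)[nH]1`: 21%

In a binding assay on isolated protein for inhibition of serine/threonine-protein kinase Chk2 (Homo sapiens), read by mobility shift assay, tested at 30 uM (a higher number here means more inhibition at the concentration tested (going by the name of the read-out), a lower number less inhibition), compound 1 stands highest of the two numbers, with compound 2 nearest; the step of a number 6 percentage points lower from compound 1 to compound 2 (within the scatter) is within the scatter. Compound 3 `Cc1cc2[nH]ncc2c(=O)[nH]1` is not yet measured; it differs from compound 1 by hydrogen in place of amino on an aromatic carbon. Among the measured compounds shown here, the single measured step concerns tert-butyl in place of methyl and does not bear on this change, so no measured precedent sets its size. The amino is expected to matter for inhibition, so a loss of inhibition beyond the scatter is estimated, a number 15 percentage points lower from compound 1 to compound 3 (beyond the scatter). For compound 3 the estimate in this assay is 12%, ranging from 0% to 28%.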

Compound 3, a percentage reported as inhibition, at one concentration (the size of the read-out at that concentration, not a potency): 12%
The estimate for compound 3 equals the measured number at the digits printed, within the range that was stated.
By their numbers in this assay, from the lowest: compounds 3, 2 and 1 (each within the scatter of the next, the first and the last beyond it).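

In this assay, among the compounds shown here, this position on the five-membered aromatic ring is sensitive to the change: hydrogen in place of amino gives a number 15 percentage points lower from compound 1 to compound 3 (beyond the scatter), the first step to clear the scatter. The earlier step, tert-butyl in place of methyl, left the amino in place and so could not show this. Nothing on hand accounts for the step. Open, from the compounds shown here alone, is whether a methylamino or acetamido group at this position would keep the inhibition seen for compound 1 27%.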